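Series notes: para substituent on the benzylamine arm

The source may report more compounds than this note shows. Statements on the series, on what has been measured and on what is new or still open speak of the compounds shown alone.

Measured compounds:
- compound 1, `CNc1nc(NCc2ccc(Cl)cc2)cc(-c2ccccn2)n1`: 3 nM
- compound 2, `CNc1nc(NCc2ccc(NC(C)=O)cc2)cc(-c2ccccn2)n1`: 2 nM
- compound 3, `CNC(=O)c1ccc(CNc2cc(-c3ccccn3)nc(NC)n2)cc1`: 8 nM

In a functional assay on HEK293 cells for agonist activity at G-protein coupled receptor 39 (Mus musculus), read by inositol phosphate accumulation (a higher number here means that more compound is needed for the effect, a lower number that less compound is needed), compound 3 gives the highest number of the three measured compounds; the nearest is compound 1, a step of a 2.7-fold higher number from compound 1 to compound 3 (0.43 log units; beyond the scatter), the furthest compound 2, a step of a 4.0-fold higher number from compound 2 to compound 3 (0.60 log units; beyond the scatter). Compound 4, `CNc1nc(NCc2ccc(N(C)C(C)=O)cc2)cc(-c2ccccn2)n1`, is not yet measured. It differs from compound 3 by acetyl(methyl)amino in place of methylcarbamoyl on an aromatic carbon.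

For the measured compounds named here, the step that bears most on this change is the one from compound 2 to compound 3, a 4.0-fold higher number from compound 2 to compound 3 (0.60 log units; beyond the scatter), in which an amide attached to the ring through nitrogen was exchanged for one attached through carbon. Compound 4 returns to a nitrogen-attached amide, now carrying a methyl on that nitrogen. Going by the values given here, no measured step shows the effect of that methyl, so the reversal is taken only in part. For compound 4 a step of a 2.7-fold lower number from compound 3 to compound 4 (0.43 log units; beyond the scatter) in this assay is therefore expected, toward a lower number. Compound 4 is estimated at 3 nM, with a range from 1 nM to 10 nM.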

Compound 4, half-maximal effective concentration: 2610 nM
Compound 4: middle estimate off by 870-fold (2.94 log units), on the low side; the whole stated range lies below it.
By their numbers in this assay, from the lowest: compounds 2 and 1 (each within the scatter of the next); then compound 3; then compound 4.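

The single methyl in place of hydrogen on the amide-type nitrogen gives a 1300-fold higher number from compound 2 to compound 4 (3.12 log units; beyond the scatter) in this assay, a far larger step than any among compounds 1, 2 and 3. For the compounds shown here, measured against the other two groups, acetyl(methyl)amino gives a 330-fold higher number from compound 3 to compound 4 (2.51 log units; beyond the scatter) and an 870-fold higher number from compound 1 to compound 4 (2.94 log units; beyond the scatter) at the same position, so this position is not as permissive as the earlier compounds suggested. Chloro in compound 1 carries no amide hydrogen either, so the absence of that hydrogen alone does not set compound 4 apart.

Nothing measured here accounts for the size of this loss. Still open, on these data alone, is whether an ethyl on the same nitrogen, or a dimethylcarbamoyl group attached through carbon, would give a similarly high number.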